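The source may hold more compounds than are shown below. What is called first, only, known or untested is meant among the compounds shown, and "the series" means these compounds.

Three compounds share one core and were tested in a functional assay on HEK293 cells for agonist activity at G-protein coupled receptor 39 (Homo sapiens), read by scintillation proximity assay and inositol phosphate accumulation, with a stated time of 75 min; on this read-out higher numbers stand for an effect only at larger amounts of compound and lower numbers for an effect already at smaller amounts. Compound 1 `Cc1cc(C)n(CCOC2CC(=O)Nc3c2c(C)nn3-c2ncnc3nc[nH]c23)n1` gives 2000 nM. Compound 2 `Cc1nn(-c2ncnc3nc[nH]c23)c2c1C(C(=O)NCc1ccccc1)CC(=O)N2` gives 2930 nM, a change described by a 1.5-fold higher number from compound 1 to compound 2 (0.17 log units; within the scatter). Compound 3 `Cc1nn(-c2ncnc3nc[nH]c23)c2c1C(NC(=O)Cc1cccs1)CC(=O)N2` gives 244 nM, the lowest number of the three; the drop is described by an 8.2-fold lower number from compound 1 to compound 3 (0.91 log units; beyond the scatter) and by a 12-fold lower number from compound 2 to compound 3 (1.08 log units; beyond the scatter), both beyond the scatter.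

Compound 4 `Cc1nn(-c2ncnc3nc[nH]c23)c2c1C(C(=O)N(C)c1ccccc1)CC(=O)N2` has not been measured. It differs from compound 3 in one place: methyl(phenyl)carbamoyl in place of (((thiophen-2-yl)methyl)carbonyl)amino on a saturated ring carbon. The most telling comparison is a 12-fold lower number from compound 2 to compound 3 (1.08 log units; beyond the scatter). Compound 2 also carries a carbamoyl group bearing a phenyl ring on that same saturated ring carbon, and its number was far higher than that of compound 3. The group entering in compound 4 is not identical to that of compound 2, so the reverse step need not be equal in size. Still, compound 4 is expected to move back toward higher numbers, with an estimated 10-fold higher number from compound 3 to compound 4 (1.01 log units; beyond the scatter). Compound 4 is therefore estimated at 2500 nM, in a range from 600 nM to 10000 nM.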

Compound 4, half-maximal effective concentration: 5220 nM
The estimate for compound 4 lay 2.1-fold (0.32 log units) below the measured number; the measured number falls inside the stated range.
By their numbers in this assay, from the lowest: compound 3; then compounds 1, 2 and 4 (each within the scatter of the next, the first and the last beyond it).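

In this assay, methyl(phenyl)amino in place of benzylamino on the carbonyl carbon gives a 1.8-fold higher number from compound 2 to compound 4 (0.25 log units; within the scatter), so these two carbamoyl compounds cannot be told apart. Methyl(phenyl)carbamoyl in place of (((thiophen-2-yl)methyl)carbonyl)amino on the saturated ring carbon gives a 21-fold higher number from compound 3 to compound 4 (1.33 log units; beyond the scatter), and the comparison with the ether-linked side chain gives a 2.6-fold higher number from compound 1 to compound 4 (0.42 log units; beyond the scatter), so the low number of compound 3 now stands against two carbamoyl compounds rather than one. No measurement here explains this difference.

Going by these compounds, the step from compound 3 to compound 4 swaps both the amide link and the aromatic ring, so it remains open which of the two matters; a phenylacetylamino group on the same carbon would separate them. On these data alone, how a carboxylic acid at this carbon would read is also open.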